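Moving one chlorine on the benzyl group of compound 3

This account rests on a few compounds, and the source may have more. Where it says the series, first, only, none or still open, it means among the compounds named here.

In a functional assay on Jurkat cells (Homo sapiens) (on this read-out higher numbers stand for weaker inhibition and lower numbers for stronger inhibition), compound 1 `C[C@H](NC(=O)C(=O)Nc1cccnc1N(C)C)C(=O)N[C@@H](CC(=O)O)C(=O)COc1c(F)c(F)cc(F)c1F` gives 27 nM and compound 2 `C[C@H](NC(=O)C(=O)NCc1ccccc1F)C(=O)N[C@@H](CC(=O)O)C(=O)COc1c(F)c(F)cc(F)c1F` gives 207 nM while compound 3 `C[C@H](NC(=O)C(=O)NCc1cc(Cl)ccc1Cl)C(=O)N[C@@H](CC(=O)O)C(=O)COc1c(F)c(F)cc(F)c1F` gives 4.3 nM as the lowest of the three numbers. Its gaps to both others lie beyond the scatter.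

The next compound, compound 4 `C[C@H](NC(=O)C(=O)NCc1cc(Cl)cc(Cl)c1)C(=O)N[C@@H](CC(=O)O)C(=O)COc1c(F)c(F)cc(F)c1F`, has the same atoms as compound 3 but joined differently: 3,5-dichlorophenyl in place of 2,5-dichlorophenyl on a saturated chain carbon bound to an amide-type nitrogen and so 3,5-dichlorophenyl stands in place of 2,5-dichlorophenyl on a saturated chain carbon bound to an amide-type nitrogen.

The closest guide is the large 48-fold lower number from compound 2 to compound 3 (1.68 log units; beyond the scatter) at that same place, which shows that the choice of ring there can matter greatly. The modest 6.3-fold lower number from compound 1 to compound 3 (0.80 log units; beyond the scatter) and the modest 7.7-fold higher number from compound 1 to compound 2 (0.88 log units; beyond the scatter) replace the whole group, so they say less. Among the measured compounds shown here, no measured pair shows a chlorine moving on its own, so the direction remains uncertain. For the measured compounds named here, with compound 3 at 4.3 nM as the lowest number so far, a rise seems likelier than a further fall.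

An estimated 3.5-fold higher number from compound 3 to compound 4 (0.54 log units; beyond the scatter) is therefore expected in this assay as a modest rise. For compound 4 the expected value is 15 nM with an estimated range from 3 nM to 80 nM around it.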

Compound 4, half-maximal inhibitory concentration: 23 nM
Beside the measured number, compound 4's estimate is 1.5-fold (0.19 log units) below it; the measured number falls inside the stated range.
By their numbers in this assay, from the lowest: compound 3; then compounds 4 and 1 (each within the scatter of the next); then compound 2.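

Compounds 3 and 4 have the same atoms and differ only in the arrangement of the two chlorines on the benzyl group, and in this assay this change alone gives a clear shift (a 5.3-fold higher number from compound 3 to compound 4 (0.73 log units; beyond the scatter)), so the chlorine pattern matters as well as the presence of the chlorines. The 3,5-dichlorobenzyl group still improves on the 2-fluorobenzyl group (a 9.0-fold lower number from compound 2 to compound 4 (0.95 log units; beyond the scatter)), but this gain is smaller than the one seen with the 2,5-dichlorobenzyl group (a 48-fold lower number from compound 2 to compound 3 (1.68 log units; beyond the scatter)). The 3,5-dichlorobenzyl group also brings no readable change from the 2-(dimethylamino)pyridin-3-yl group of compound 1 (a 1.2-fold lower number from compound 1 to compound 4 (0.07 log units; within the scatter)), so only the 2,5-dichlorobenzyl group of compound 3 stands clearly ahead of that group.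

No supporting measurement explains why the chlorine arrangement alters the number in this way. The compounds shown also leave open how a benzyl group carrying a single chlorine, or a trifluoromethyl group in place of either chlorine, would compare with the 2,5-dichlorobenzyl group.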